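This account rests on a few compounds, and the source may have more. Where it says the series, first, only, none or still open, it means among the compounds named here.

Compound 3, `CC(C)OC(=O)N1CCC(Oc2ncnc3c2CCN3c2ccc(C#N)c(F)c2)CC1`, gives the largest maximal response of the three measured compounds in a functional assay on CHO-K1 cells with Glucose-dependent insulinotropic receptor (Homo sapiens) as the target, read by a luciferase reporter, with a stated time of 5 h; on this read-out lower numbers stand for smaller maximal responses and higher numbers for larger maximal responses: compound 3 reaches 121%. Compound 2, `CC(C)OC(=O)N1CCC(Oc2ncnc3c2CCN3c2ccc(S(C)(=O)=O)nc2)CC1`, gives 97%, and compound 1, `CC(C)OC(=O)N1CCC(Oc2ncnc3c2CCN3c2ccc(S(C)(=O)=O)cc2F)CC1`, gives 91%. The step of a number 24 percentage points higher from compound 2 to compound 3 (beyond the scatter) and the step of a number 30 percentage points higher from compound 1 to compound 3 (beyond the scatter) both lie beyond the scatter, so compound 3 stands clearly above the other two, while compound 1 and compound 2 lie within the scatter of each other.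

Compound 4, `CC(C)OC(=O)N1CCC(Oc2ncnc3c2CCN3c2ccc([S@+](C)[O-])c(F)c2)CC1`, differs from compound 3 in one place: a group of 3 heavy atoms (1 carbon, 1 oxygen, 1 sulfur; no ring) in place of a group of 2 heavy atoms (1 carbon, 1 nitrogen; no ring), on an aromatic carbon. For the measured compounds named here, no measured step exchanges the cyano group alone, so the bearing of the earlier steps is indirect. Both steps that lead to compound 3 replaced a ring carrying a methylsulfonyl group with the 4-cyano-3-fluorophenyl group and raised the response by a modest amount; compound 4 now brings a sulfur- and oxygen-containing group back onto the ring in place of cyano. Going by the values given here, a modest decrease is therefore expected, though it may not exceed the scatter, since the earlier steps also changed other parts of the ring. Compound 4 is estimated to reach 102% in this assay, in a range of 80% to 124%, meaning an expected step of a number 19 percentage points lower from compound 3 to compound 4 (beyond the scatter).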

Compound 4, largest response reached (reported as percent of maximum), in percent of the reference or control that the assay uses: 122%
For compound 4 the middle estimate is 20 percentage points below the measured one; the range from low to high includes it.
By their numbers in this assay, from the lowest: compounds 1 and 2 (each within the scatter of the next); then compounds 3 and 4 (each within the scatter of the next).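

In this assay, putting the group of 3 heavy atoms (1 carbon, 1 oxygen, 1 sulfur) in place of cyano on this aromatic carbon gives a number 1 percentage points higher from compound 3 to compound 4 (within the scatter) and so leaves the maximal response unchanged within the usual variation between repeats. The position therefore accepts more than the cyano group at this high level of response, and carrying sulfur and oxygen here does not by itself go with a smaller response. The high level also separates compound 4 from the two compounds with a methylsulfonyl group, with a number 25 percentage points higher from compound 2 to compound 4 (beyond the scatter) and a number 31 percentage points higher from compound 1 to compound 4 (beyond the scatter) as the two steps, yet no information is available on why the new group matches cyano or stands apart from those rings.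

From the compounds shown here alone, whether the response would hold with an amine or a carboxylic acid on this aromatic carbon remains open, as does the effect of removing the fluoro group beside which the new group sits in the printed description, ortho to it. Compound 4 also has one defined stereocentre, and the shown compounds do not tell whether the opposite arrangement at that sulfur would behave the same way.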